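Pyrazine hydrazones on macrophage viability: a dimethylamino swap

The source may hold more compounds than are shown below. What is called first, only, known or untested is meant among the compounds shown, and "the series" means these compounds.

The measured compounds are compound 1 `CCOc1ccc(/C=N/NC(=O)c2cnccn2)cc1`, compound 2 `O=C(N/N=C/c1ccc(O)cc1)c1cnccn1` and compound 3 `N#Cc1ccc(/C=N/NC(=O)c2cnccn2)cc1`. In an ADME assay on J774 cells (Mus musculus) for cytotoxicity, read by MTT assay, with a stated time of 48 h, tested at 100 ug/mL (a lower number here means a stronger effect, a higher number a weaker effect of the compound at the concentration tested), compound 1 gives 98%, compound 2 gives 81% and compound 3 gives 100%.

Compound 3 stands highest of the three numbers. Its nearest neighbour is compound 1, whose value lies within the scatter of its own; the furthest is compound 2, which sits beyond the scatter below it. Compound 4 `CN(C)c1ccc(/C=N/NC(=O)c2cnccn2)cc1` is the next compound to be measured in this assay. It differs from compound 3 in one place: dimethylamino in place of cyano on an aromatic carbon.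

For the measured compounds named here, two measured steps touch the same position. Changing the group there gave a number 2 percentage points higher from compound 1 to compound 3 (within the scatter), a step within the scatter, and a number 19 percentage points higher from compound 2 to compound 3 (beyond the scatter), a modest step beyond it. Both point to the group on that aromatic carbon mattering little unless it is hydroxy. Going by the values given here, no measured compound carries a dimethylamino group, so nothing directly tells how that group behaves here. With the shared core unchanged and neighbouring changes largely quiet, compound 4 is expected to stay near compound 3, with a step of a number 5 percentage points lower from compound 3 to compound 4 (within the scatter) at most, hardly beyond the scatter. The estimated value for compound 4 is 95%, expected to fall between 80% and 104%.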

Compound 4, a percentage reported as activity, at one concentration (the size of the read-out at that concentration, not a potency): 87%
Compound 4: the middle estimate sits 8 percentage points above what was measured, and the stated range covers the measured number.
By their numbers in this assay, from the lowest: compounds 2 and 4 (each within the scatter of the next); then compounds 1 and 3 (each within the scatter of the next).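

With the step of a number 13 percentage points lower from compound 3 to compound 4 (beyond the scatter) in this assay, and the step of a number 11 percentage points lower from compound 1 to compound 4 (beyond the scatter) in the same assay, dimethylamino becomes the second group at this aromatic carbon, after hydroxy, to stand apart from both cyano and ethoxy, so the earlier reading that only hydroxy mattered here no longer holds. The step of a number 6 percentage points higher from compound 2 to compound 4 (within the scatter) leaves the dimethylamino and hydroxy compounds unresolved from each other, and the four compounds fall into two sets, compounds 2 and 4 on one side and compounds 1 and 3 on the other; cyano and dimethylamino have the same counts of hydrogen-bond donors and acceptors, so those counts do not separate the two sets. No available evidence gives a reason for this grouping.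

From the compounds shown here alone, whether a plain amino group or a carboxylic acid on the same aromatic carbon would fall with compounds 2 and 4 or with compounds 1 and 3 remains open. Also open, going by these compounds, is whether a longer chain on the nitrogen, such as diethylamino in place of dimethylamino, would keep the number where compound 4 puts it.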